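Amide-tail swap on the core of compound 3

The compounds below may be only part of what the source reports. "The series", "measured", "known", "first", "only" and "open" are said of these compounds alone.

Measured in an assay on cells for agonist activity at vitamin D3 receptor (Homo sapiens), read by microscopy; a lower number here means that less compound is needed, a higher number that more compound is needed for the effect:
compound 1 `CCn1c(C(=O)NCCC(=O)OC)ccc1C(CC)(CC)c1ccc(C#CC(O)(CC)CC)c(C)c1` gives the limit > 50 nM.
compound 2 `CCn1c(C(=O)NCCCO)ccc1C(CC)(CC)c1ccc(C#CC(O)(CC)CC)c(C)c1` gives 137 nM.
compound 3 `CCn1cc(C(CC)(CC)c2ccc(C#CC(O)(CC)CC)c(C)c2)cc1C(=O)NCC(=O)OC` gives 288 nM.

Compound 3 holds the highest of the two numbers shown; its nearest neighbour is compound 2, whose number is lower by a gap beyond the scatter. The value of compound 1 is a limit of this assay and not a number (the limit of > 50 nM in this assay, at which 1 of the 3 values shown sits). Compound 4 `CCn1cc(C(CC)(CC)c2ccc(C#CC(O)(CC)CC)c(C)c2)cc1C(=O)NCCN(C)C` carries (dimethylamino)methyl in place of methoxycarbonyl on a saturated chain carbon bound to an amide-type nitrogen. Within the data shown here, the only measured step in the same tail region, a step that the limit leaves unreadable from compound 1 to compound 2, starts from a limit and its size cannot be read, so no measured step gives a size for the present change. The step into compound 4 is therefore expected to stay within the scatter: a 1.2-fold lower number from compound 3 to compound 4 (0.06 log units; within the scatter). Compound 4 is estimated at 250 nM, between 80 nM and 800 nM.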

Compound 4, half-maximal effective concentration: 19.3 nM
Estimate against measurement, compound 4: 13-fold (1.11 log units) above, outside the stated range (below it).
By their numbers in this assay, from the lowest: compound 4; then compound 2; then compound 3.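

With (dimethylamino)methyl in place of methoxycarbonyl on a saturated chain carbon bound to an amide-type nitrogen, the result is a 15-fold lower number from compound 3 to compound 4 (1.17 log units; beyond the scatter). Among these compounds, this is the first readable size for a change in this tail, as the step from compound 1 to compound 2 starts from a limit and cannot be read. Nothing measured here bears on the cause of this large step.

Still open, on these data alone, is whether the amine itself carries the step, or whether a carboxylic acid, a primary amine or a longer chain before the dimethylamino group would give a similar number on this core.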